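The compounds below may be only part of what the source reports. "The series", "measured", "known", "first", "only" and "open" are said of these compounds alone.

Measured so far:
compound 1, `Cc1ccccc1-c1nn(-c2ccc(Cl)cc2)cc1CNCCN1CCN(C)CC1` — 17000 nM
compound 2, `CN1CCN(CCNCc2cn(-c3ccc(C(F)(F)F)cc3)nc2-c2ccc(C(F)(F)F)cc2)CC1` — 1500 nM

Compound 1 stands at the highest of the two numbers in an ADME assay on Huh-7 cells (Homo sapiens) for cytotoxicity; on this read-out lower numbers stand for higher toxicity in this test and higher numbers for lower toxicity in this test. The nearest value is that of compound 2, which in this assay gives 1500 nM, a gap from compound 1 that lies beyond the scatter, so compound 1 is the less toxic of the pair in this test. Among the measured compounds shown here, no two measured compounds differ in a single place, so no step can be read off directly.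

Compound 3, `Cc1ccccc1-c1nn(Cc2ccccc2)cc1CNCCN1CCN(C)CC1`, is the next compound to be measured in this assay. It differs from compound 1 as follows: benzyl in place of 4-chlorophenyl on an aromatic nitrogen. For the measured compounds named here, with no comparable step among the measured compounds, the change is expected to move the number by a step of a 1.2-fold higher number from compound 1 to compound 3 (0.07 log units; within the scatter), which is judged to fall within the scatter, with perhaps a lean toward a higher value. For compound 3 the expected value in this assay is 20000 nM, in the range 7000 nM to 50000 nM.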

Compound 3, half-maximal cytotoxic concentration: > 20000 nM
Compound 3: a limit, no number; the forecaster's own chance of this, stated with the estimate: 25%; the middle value sits exactly at the limit.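

Among the compounds shown here, this is the first single-place step, and it sits on an aromatic nitrogen of the five-membered ring: benzyl in place of 4-chlorophenyl gives an at least 1.1-fold higher number from compound 1 to compound 3 (0.07 log units; that floor lies within the scatter). In this assay, compound 3 gives > 20000 nM, which is a limit and not a number. The change therefore shows no fall in the number at this position, but only a floor can be read for the step, and its true size remains unfixed: the limit of > 20000 nM in this assay, at which 1 of the 3 values shown sits.

The compounds shown leave open whether the loss of chlorine or the insertion of the methylene link matters more, a split that plain phenyl or 4-chlorobenzyl on this nitrogen would address. On these data alone, how a longer chain such as 2-phenylethyl, or an amine on the benzyl ring, would read here also remains open.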